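Swapping a Halogenated Phenyl Ring on a Shared Core

A few compounds are considered here, and "the series" means these few. Any claim that something is new, unique, unknown or untested is made for them only; others in the source may bear on it.

Compound 1 `O=C(O)c1csc([C@H]2CC[C@@H]3[C@@H](COc4cccc(F)c4)[C@H](O)C[C@@H]3O2)n1`: in an assay on HEK293 cells for agonist activity at prostaglandin E2 receptor EP2 subtype (Homo sapiens), read by a beta-galactosidase reporter and beta-arrestin recruitment, with a stated time of 90 min (a higher number here means that more compound is needed for the effect, a lower number that less compound is needed), compound 1 gives > 10000 nM, which is a limit of the assay, not a number.
Compound 2 `O=C(O)c1csc([C@H]2CC[C@@H]3[C@@H](CCCCCOc4ccccc4)[C@H](O)C[C@@H]3O2)n1`: in this assay compound 2 gives > 10000 nM, also a limit.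
Compound 3 `O=C(O)c1csc([C@H]2CC[C@@H]3[C@@H](/C=C/CCOc4ccccc4)[C@H](O)C[C@@H]3O2)n1`: in this assay compound 3 gives > 10000 nM, again a limit.

All three measured compounds share the same core and differ only in the chain carried on it, and none of them yields a number. Among the measured compounds shown here, compound 1 therefore stands at the limit of > 10000 nM in this assay, at which 3 of the 3 values shown sit, with no measured compound placed above or below it. The compound still to be measured, compound 4 `O=C(O)c1csc([C@H]2CC[C@@H]3[C@@H](COc4ccccc4Cl)[C@H](O)C[C@@H]3O2)n1`, differs from compound 1 in one place: 2-chlorophenyl in place of 3-fluorophenyl on an oxygen on a saturated carbon. For the measured compounds named here, no step between two measured compounds is available, so these data do not show how such an exchange moves the value. The known neighbours, compound 2 and compound 3 with longer chains, also sit at the limit. The expectation for compound 4 is that it stays near that limit, so the estimated step that the limit leaves unreadable from compound 1 to compound 4 is none beyond the scatter. Compound 4 is expected to give about 15000 nM, within a range of 3000 nM to 60000 nM, most likely reported again only as a limit.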

Compound 4, half-maximal effective concentration: 203 nM
For compound 4 the middle estimate is 74-fold (1.87 log units) above the measured one, outside the stated range (below it).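

In this assay, exchanging 3-fluorophenyl for 2-chlorophenyl on the oxygen gives an at least 49-fold lower number from compound 1 to compound 4 (1.69 log units; beyond the scatter), so this ring is a place where a small exchange can turn a compound with no readable value into one with a measured value. Among the compounds shown here, compound 4 is the only one of the four compounds that leaves the group held at the assay limit, while the shared core and the short chain stay the same: the limit of > 10000 nM in this assay, at which 3 of the 4 values shown sit. The two rings match in heavy atom count, hydrogen-bond donors, hydrogen-bond acceptors and net charge, so these counts do not separate them, and the difference lies in which halogen the ring carries and where it stands.

The halogen and its place on the ring change together in this single exchange, so the compounds shown cannot tell which of the two accounts for the step. They also give no value for a plain phenyl ring on this short chain, or for a ring carrying bromine or a methyl group in place of the chlorine.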